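The compounds below may be only part of what the source reports. "The series", "measured", "known", "first", "only" and "open" are said of these compounds alone.

Working notes on the series. Among the compounds with values here, in a functional assay on HepG2 cells (Homo sapiens) for inhibition, read by MTT assay, with a stated time of 48 h (a higher number here means a weaker inhibitor, a lower number a stronger inhibitor), compound 1 (`Cc1ccc(-c2nc3ccccn3c2Sc2ccccc2)cc1`) gives 67900 nM and compound 2 (`N#Cc1ccc(-c2nc3ccccn3c2Sc2ccccc2)cc1`) gives 15700 nM, so compound 2 holds the lower of the two numbers so far. Next is compound 3 (`c1ccc(Sc2c(-c3cccs3)nc3ccccn23)cc1`), which carries thiophen-2-yl in place of 4-cyanophenyl on an aromatic carbon. Within the data shown here, only one measured step bears on this change: a 4.3-fold lower number from compound 1 to compound 2 (0.64 log units; beyond the scatter), with cyano in place of methyl. That step is a modest one and alters only the group carried on the aromatic ring, so it is an indirect guide. Compound 3 has no cyano group, so a modest step of similar size towards a higher number is expected in this assay. The expected step is a 2.2-fold higher number from compound 2 to compound 3 (0.35 log units; beyond the scatter). For compound 3 the estimated value is 35000 nM, with an expected range of 12000 nM to 100000 nM.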

Compound 3, half-maximal inhibitory concentration: 17100 nM
For compound 3 the middle estimate is 2.0-fold (0.31 log units) above the measured one; the range from low to high includes it.
By their numbers in this assay, from the lowest: compounds 2 and 3 (each within the scatter of the next); then compound 1.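

In this assay, thiophen-2-yl at this aromatic carbon, with one five-membered aromatic ring in place of the six-membered carbon ring of 4-cyanophenyl, leaves the number unchanged within the scatter (a 1.1-fold higher number from compound 2 to compound 3 (0.04 log units; within the scatter)). Against 4-methylphenyl the same exchange gives a 4.0-fold lower number from compound 1 to compound 3 (0.60 log units; beyond the scatter), so among these compounds the nitrile is not required for the lower numbers: compound 3 has none and still stands level with compound 2. No measurement on hand accounts for this.

From the compounds shown here alone, what a non-aromatic group at this place, such as an amine or a carboxylic acid on a short chain, would do remains open. Going by these compounds, all three compounds also keep the phenylsulfanyl group, so the contribution of that neighbouring group remains open too.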